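Aryl sulfonamides on a cyclopropyl-oxazole core: growth inhibition

This account rests on a few compounds, and the source may have more. Where it says the series, first, only, none or still open, it means among the compounds named here.

Measured compounds:
compound 1 `O=S(=O)(Nc1cccc(Cl)c1)c1ccc(-c2cnc(C3CC3)o2)cc1`: 54200 nM
compound 2 `Cc1ccc(NS(=O)(=O)c2ccc(-c3cnc(C4CC4)o3)cc2)cc1C`: > 100000 nM
compound 3 `Cc1cc(Cl)ccc1NS(=O)(=O)c1ccc(-c2cnc(C3CC3)o2)cc1`: 54700 nM

The series keeps a shared core and varies only the aryl group on the sulfonamide nitrogen. In a functional assay on cells (leukaemia cell line, Homo sapiens) for inhibition, read by sulforhodamine B assay, with a stated time of 48 h (on this read-out lower numbers stand for stronger inhibition of growth and higher numbers for weaker inhibition of growth), compound 1 gives 54200 nM. Compound 3 gives 54700 nM in this assay, and the step of a 1.0-fold higher number from compound 1 to compound 3 (0.00 log units; within the scatter) lies within the scatter. Compound 2 stands apart: in this assay compound 2 returns only a limit of the assay, > 100000 nM, so its true number is not known, and the limit of > 100000 nM in this assay, at which 1 of the 3 values shown sits, records that one of the three values sits there. The steps of an at least 1.8-fold higher number from compound 1 to compound 2 (0.26 log units; that floor lies within the scatter) and an at least 1.8-fold lower number from compound 2 to compound 3 (0.26 log units; that floor lies within the scatter) therefore have floors only, and both floors lie within the scatter.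

Compound 4 `Cc1cc(Cl)cc(NS(=O)(=O)c2ccc(-c3cnc(C4CC4)o3)cc2)c1` has not yet been measured. It differs from compound 2 by 3-chloro-5-methylphenyl in place of 3,4-dimethylphenyl on a sulfonamide nitrogen. Going by the values given here, the bearing steps are those just named, and none is resolved beyond the scatter; the only finished number in the same region comes from compound 1, which carries a chlorine on the ring that compound 4 also carries. Compound 4 is therefore expected to sit near compound 1, estimated at 55000 nM (range 25000 nM to 120000 nM), which would mean an expected step of an at least 1.8-fold lower number from compound 2 to compound 4 (0.25 log units; that floor lies within the scatter).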

Compound 4, concentration for total growth inhibition: 7040 nM
Compound 4: the middle estimate sits 7.8-fold (0.89 log units) above what was measured, and the stated range ends above it.
By their numbers in this assay, from the lowest: compound 4; then compounds 1 and 3 (each within the scatter of the next). At a limit, above all of these: compound 2.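

In this assay, going by these compounds alone, methyl in place of hydrogen on an aromatic carbon gives a 7.7-fold lower number from compound 1 to compound 4 (0.89 log units; beyond the scatter), while moving the same chlorine and methyl groups from 4-chloro-2-methylphenyl to 3-chloro-5-methylphenyl gives a 7.8-fold lower number from compound 3 to compound 4 (0.89 log units; beyond the scatter), so the arrangement of these groups on the ring matters and not only their presence, and these are the first steps with finished numbers at both ends that lie beyond the scatter. Chlorine and methyl in the 3-chloro-5-methylphenyl arrangement also separate from 3,4-dimethylphenyl, with an at least 14-fold lower number from compound 2 to compound 4 (1.15 log units; beyond the scatter), which is a floor and not a finished step. Compound 2 carries only a limit of the assay: the limit of > 100000 nM in this assay, at which 1 of the 4 values shown sits.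

The compounds shown leave open whether the stronger inhibition of growth belongs to methyl in particular, or whether an ethyl, a methoxy or a second chlorine on the same ring would serve as well. They also leave open whether the chlorine of compound 4 is needed at all, or whether a trifluoromethyl or a nitrile could stand in its place.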